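The source may hold more compounds than are shown below. What is called first, only, known or untested is meant among the compounds shown, and "the series" means these compounds.

In a functional assay on the whole organism with Mus musculus as the target (on this read-out higher numbers stand for an effect only at larger amounts of compound and lower numbers for an effect already at smaller amounts), two compounds with the same core have been measured so far. Compound 1 `NC(=O)Cn1c(-c2ccc(Cl)cc2)nc2cccnc21` gives 4.1 mg/kg and compound 2 `CCCN(C)C(=O)Cn1c(-c2ccc(Cl)cc2)nc2cccnc21` gives 11.6 mg/kg as the higher of the two numbers, so compound 2 needs the larger dose. Within the data shown here, the only measured step is a 2.8-fold higher number from compound 1 to compound 2 (0.45 log units; beyond the scatter) and it comes with methyl(propyl)amino in place of amino on a carbonyl carbon.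

Compound 3 `O=C(Cn1c(-c2ccc(Cl)cc2)nc2cccnc21)N1CCCC1` has not been measured yet, and it differs from compound 2 at that same carbonyl carbon. The whole change is pyrrolidin-1-yl in place of methyl(propyl)amino on a carbonyl carbon and it means that an open chain gives way to a ring. Among the measured compounds shown here, the one measured step bears on this only loosely, since it concerns the same place but involves no ring, and no measured compound carries a ring there. The best starting point is therefore compound 2 at 11.6 mg/kg as the closest measured structure, and no shift beyond the scatter is expected. The expected step is a 1.3-fold lower number from compound 2 to compound 3 (0.11 log units; within the scatter) and would be a small one. For compound 3 the estimated value is 9 mg/kg with an expected range from 3.5 mg/kg to 23 mg/kg as the likely span.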

Compound 3, dose for half-maximal effect: 17.9 mg/kg
Compound 3: the middle estimate sits 2.0-fold (0.30 log units) below what was measured; low and high end bracket the measured number.
By their numbers in this assay, from the lowest: compound 1; then compounds 2 and 3 (each within the scatter of the next).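

In this assay, among these compounds, a ring stands on the carbonyl carbon for the first time, and pyrrolidin-1-yl in place of methyl(propyl)amino, with the same count of heavy atoms, gives a difference that cannot be told from the scatter (a 1.5-fold higher number from compound 2 to compound 3 (0.19 log units; within the scatter)). Among these compounds, then, tying the open chain into a five-membered ring does not set the amide apart from its open-chain counterpart, whereas the ring, like the chain, stands clearly apart from the plain amino group (a 4.4-fold higher number from compound 1 to compound 3 (0.64 log units; beyond the scatter)). Nothing available on these compounds explains why the plain amino group needs the smaller dose, and so the reason for this difference stays unknown.

Still open, on these data alone, is where a small group such as methylamino or dimethylamino would fall, whether close to compound 1 or close to compound 2 and compound 3. Also open, as far as these compounds go, is whether a six-membered ring such as piperidin-1-yl or morpholin-4-yl on the same carbonyl carbon would behave like pyrrolidin-1-yl, or whether the result holds only for this one ring.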